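Hydrazone series: removing trifluoromethyl from compound 1

The compounds below may be only part of what the source reports. "The series", "measured", "known", "first", "only" and "open" are said of these compounds alone.

Measured in a functional assay on PC-3 cells (Homo sapiens) for inhibition; a lower number here means a stronger inhibitor, a higher number a weaker inhibitor:
compound 1 `Cc1c(C(=O)N/N=C\c2ccccc2C(F)(F)F)oc2cccc(O)c12` gives 26200 nM
compound 2 `Cc1c(C(=O)N/N=C\c2ccc(O)cc2)oc2cccc(O)c12` gives 21700 nM
compound 3 `Cc1c(C(=O)N/N=C\c2ccc(C(F)(F)F)cc2)oc2cccc(O)c12` gives only a limit of the assay, >= 40000 nM

Compound 1 and compound 2 lie within the scatter of each other in this assay, so neither is set apart. Compound 4 `Cc1c(C(=O)N/N=C\c2ccccc2)oc2cccc(O)c12` is the untested member; its change from compound 1 is hydrogen in place of trifluoromethyl on an aromatic carbon. Within the data shown here, the one measured step that touches trifluoromethyl is an at least 1.8-fold higher number from compound 2 to compound 3 (0.26 log units; that floor lies within the scatter), where trifluoromethyl enters. Compound 3 sits at the limit of >= 40000 nM in this assay, at which 1 of the 3 values shown sits. Taking trifluoromethyl away is therefore expected to move the number little in this assay, if anything slightly lower. Compound 4 is estimated at 20000 nM, between 8000 nM and 50000 nM. That estimate means a 1.3-fold lower number from compound 1 to compound 4 (0.12 log units; within the scatter), expected to stay within the scatter.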

Compound 4, half-maximal inhibitory concentration: 29200 nM
For compound 4 the middle estimate is 1.5-fold (0.16 log units) below the measured one; low and high end bracket the measured number.
By their numbers in this assay, from the lowest: compounds 2, 1 and 4 (each within the scatter of the next). At a limit, above all of these: compound 3.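

In this assay the aromatic carbon ortho to a large group tolerates loss of trifluoromethyl, with the step staying within the scatter (a 1.1-fold higher number from compound 1 to compound 4 (0.05 log units; within the scatter)). Hydrogen in place of hydroxy also stays within the scatter (a 1.3-fold higher number from compound 2 to compound 4 (0.13 log units; within the scatter)), and against compound 3 only a floor can be read (an at least 1.3-fold lower number from compound 3 to compound 4 (0.13 log units; that floor lies within the scatter)). Compound 3 remains a limit of the assay: the limit of >= 40000 nM in this assay, at which 1 of the 4 values shown sits.

Going by these compounds, whether an amine or a carboxylic acid on this carbon would move the number beyond the scatter stays open.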